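Stability in buffer: compounds 1 to 4

The source may report more compounds than this note shows. Statements on the series, on what has been measured and on what is new or still open speak of the compounds shown alone.

compound 1 `CC(C)OC(=O)c1cccc(NC(=O)[C@@H]2C[C@H](SC3=C(C(=O)O)N4C(=O)[C@H]([C@@H](C)O)[C@H]4[C@H]3C)CN2)c1`: > 95%
compound 2 `CCC(CC)C(=O)OCOC(=O)C1=C(S[C@@H]2CN[C@H](C(=O)Nc3cccc(C(=O)O)c3)C2)[C@H](C)[C@@H]2[C@@H]([C@@H](C)O)C(=O)N12`: > 95%
compound 3 `CCC(CC)C(=O)OCOC(=O)C1=C(S[C@@H]2CN[C@H](C(=O)Nc3cccc(C(=O)OCOC(=O)C(CC)CC)c3)C2)[C@H](C)[C@@H]2[C@@H]([C@@H](C)O)C(=O)N12`: > 95%

In a physicochemical assay for metabolic stability, read by LC-MS, in phosphate buffer, with a stated time of 3 h, at pH 7.4, tested at 50 uM (on this read-out higher numbers stand for a more stable compound and lower numbers for a less stable compound), compound 1 gives > 95%, which is a limit of the assay and not a number. In this assay compound 2 likewise gives > 95%, again a limit. Compound 3 gives > 95% in this assay, also a limit. Every value shown therefore sits at the same limit, as the evidence the limit of > 95% in this assay, at which 3 of the 3 values shown sit, records. For the measured compounds named here, the single measured step, a step that the two limits leave unreadable from compound 2 to compound 3, is unreadable from its two ends, so no size can be attached to it, and it concerns a different position from the one changed here.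

Compound 4 `COC(=O)OCOC(=O)C1=C(S[C@@H]2CN[C@H](C(=O)Nc3cccc(C(=O)O)c3)C2)[C@H](C)[C@@H]2[C@@H]([C@@H](C)O)C(=O)N12` differs from compound 2 by methoxy in place of pentan-3-yl on a carbonyl carbon. Going by the values given here, no measured step bears on this change. Among the compounds with values here, with compound 2 at the limit > 95% and no step that moves away from that limit, compound 4 is expected to stay there as well, and the step that the limit leaves unreadable from compound 2 to compound 4 is expected to be none beyond the scatter. The estimate for compound 4 in this assay is 96%, with a range from 88% to 100%, most likely reported only as a limit.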

Compound 4, percent of the compound remaining: > 95%
Compound 4: no number, only a limit (the forecaster's own chance of this, stated with the estimate: 80%); the middle value lies beyond the limit too.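

No step can be read between compound 2 and compound 4, as both values in this assay are limits and not numbers: the limit of > 95% in this assay, at which 4 of the 4 values shown sit.

Any order of stability among compound 1, compound 2, compound 3 and compound 4 in this assay stays open, with none of them shown away from that limit.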